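This account rests on a few compounds, and the source may have more. Where it says the series, first, only, none or still open, it means among the compounds named here.

Measured compounds:
- compound 1, `CCN(CC)CCn1cnnc1-c1cc(Oc2ccc(NC(=O)Nc3ccc(F)c(Cl)c3)cc2F)ccn1`: in a functional assay on HT-29 cells (Homo sapiens) for antiproliferative activity, read by MTT assay, with a stated time of 72 h (on this read-out lower numbers stand for stronger inhibition and higher numbers for weaker inhibition), compound 1 gives 500 nM
- compound 2, `CN(C)CCCn1cnnc1-c1cc(Oc2ccc(NC(=O)Nc3ccc(F)c(F)c3)cc2F)ccn1`: in this assay compound 2 gives 1210 nM

Compound 2 stands at the highest of the two numbers; its nearest neighbour is compound 1, whose number is lower by a margin beyond the usual scatter. The two differ in more than one place, so nothing is attributed to either change alone.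

Compound 3, `CN(C)CCCn1cnnc1-c1cc(Oc2ccc(NC(=O)Nc3ccc(F)c(Cl)c3)cc2F)ccn1`, keeps the amine chain of compound 2 and differs from it only in chloro in place of fluoro on an aromatic carbon. Among the compounds with values here, no measured pair shows this change by itself. Compound 1 carries the same chloro group and sits lower than compound 2, so the step in this assay from compound 2 to compound 3 is expected to be downward, of modest size, though it could also fall within the scatter. The expected step is a 1.6-fold lower number from compound 2 to compound 3 (0.21 log units; within the scatter). Compound 3 is therefore estimated at 750 nM, with a plausible range from 300 nM to 1600 nM.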

Compound 3, half-maximal inhibitory concentration: 890 nM
For compound 3 the middle estimate is 1.2-fold (0.07 log units) below the measured one, and the stated range covers the measured number.
By their numbers in this assay, from the lowest: compounds 1, 3 and 2 (each within the scatter of the next, the first and the last beyond it).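

In this assay, within the data shown here, chloro in place of fluoro on an aromatic carbon, ortho to a fluoro group, gives a 1.4-fold lower number from compound 2 to compound 3 (0.13 log units; within the scatter); this is the first reading of that change alone, and it does not separate the two compounds. With the chloro group held constant, (dimethylamino)methyl in place of diethylamino on a saturated chain carbon gives a 1.8-fold higher number from compound 1 to compound 3 (0.25 log units; within the scatter), so this change alone does not separate its two compounds either. Nothing measured bears on the reason for either step.

Open, from the compounds shown here alone, is whether bromo, methyl or methoxy at this aromatic position would give a step beyond the scatter. Also open, going by these compounds, is how a morpholine or piperidine at the chain end, or a longer chain, would read in this assay.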